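The source may hold more compounds than are shown below. What is called first, only, known or untested is meant among the compounds shown, and "the series" means these compounds.

Compound 1 `O=C(Nc1ccc(Sc2nc3ccccc3s2)cc1)c1cc(Br)cc(Br)c1O` was examined in an assay on isolated protein for inhibition of thiosulfate sulfurtransferase (Homo sapiens), with a stated time of 60 min, in the absence of a further agent; on this read-out higher numbers stand for weaker inhibition and lower numbers for stronger inhibition. In this assay compound 1 gives > 100000 nM, which is a limit of the assay rather than a number. The two other compounds measured show the same. Compound 2 `COc1c(Br)cccc1C(=O)Nc1ccc(Sc2nc3ccccc3s2)c(Cl)c1` gives > 100000 nM, a limit. Compound 3 `COc1c(Br)cccc1C(=O)Nc1cccc(Cl)c1` gives > 100000 nM, also a limit. In short, (the limit of > 100000 nM in this assay, at which 3 of the 3 values shown sit). Compound 4 `O=C(Nc1ccc(Sc2nc3ccccc3s2)cc1)c1cccc(Br)c1O` has not yet been measured; it differs from compound 1 in one place: hydrogen in place of bromo on an aromatic carbon. Going by the values given here, no measured step between two compounds is available, so the effect of this change cannot be read off from the data. Since compound 1 sits at the limit with > 100000 nM, no step beyond the scatter is expected in either direction. Compound 4 is therefore estimated at about 100000 nM, between 30000 nM and 300000 nM. The step this estimate means, a number no higher from compound 1 to compound 4 (the limit leaves the size open), is expected to lie within the scatter.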

Compound 4, half-maximal inhibitory concentration: > 100000 nM
Compound 4: a limit, no number (the forecaster's own chance of this, stated with the estimate: 80%); the middle value lies on the limit itself.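

Going by these compounds alone, compound 1 and compound 4 both sit at a limit, so no step between them can be read: the limit of > 100000 nM in this assay, at which 4 of the 4 values shown sit.

On these data alone, what swapping bromo for hydrogen does in this assay stays open, as does which structures, if any, would give a number rather than a limit.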